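The source may report more compounds than this note shows. Statements on the series, on what has been measured and on what is new or still open speak of the compounds shown alone.

Measured in a functional assay on CEM-SS cells (Homo sapiens) for cytotoxicity; on this read-out higher numbers stand for weaker inhibition and lower numbers for stronger inhibition:
Compound 1 `COc1ccc(Cn2c(N)nc3cc(Cl)c(Cl)cc32)cc1`: 27000 nM
Compound 2 `COc1ccc(Cn2c(Cl)nc3cc(Cl)c(Cl)cc32)cc1`: > 100000 nM, a limit
Compound 3 `Clc1ccc(Cn2c(Br)nc3cc(Cl)c(Cl)cc32)cc1`: > 100000 nM, a limit

Compound 3 stands only at a limit, so it offers no exact number to start from. Compound 4 `COc1ccc(Cn2c(Br)nc3cc(Cl)c(Cl)cc32)cc1` differs from it by methoxy in place of chloro on an aromatic carbon, para to a large group (methoxy in place of chloro on an aromatic carbon). Within the data shown here, the one measured step, an at least 3.7-fold higher number from compound 1 to compound 2 (0.56 log units; beyond the scatter), concerns a different exchange and bears only indirectly. Compound 2, which also carries the methoxy, sits at a limit of > 100000 nM. No step beyond the scatter is therefore expected in this assay. The expected step, a number no higher from compound 3 to compound 4 (the limit leaves the size open), is an estimate only. For compound 4 the estimated value is 100000 nM, with an expected range of 40000 nM to 150000 nM.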

Compound 4, half-maximal inhibitory concentration: 60000 nM
For compound 4 the middle estimate is 1.7-fold (0.22 log units) above the measured one; the range from low to high includes it.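

In this assay, methoxy in place of chloro on an aromatic carbon, para to a large group, gives an at least 1.6-fold lower number from compound 3 to compound 4 (0.22 log units; that floor lies within the scatter), so the bromo compound with methoxy has an exact number rather than a limit. At the other changed place, bromo in place of chloro gives an at least 1.6-fold lower number from compound 2 to compound 4 (0.22 log units; that floor lies within the scatter), while bromo in place of amino gives a 2.2-fold higher number from compound 1 to compound 4 (0.35 log units; beyond the scatter). The two steps that start from a limit have no fixed size: the limit of > 100000 nM in this assay, at which 2 of the 4 values shown sit.

On these data alone, how a carboxylic acid or an ethoxy chain in place of the methoxy would read in this assay remains open.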